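The source may report more compounds than this note shows. Statements on the series, on what has been measured and on what is new or still open speak of the compounds shown alone.

Measured compounds:
- compound 1, `COc1ccc(-c2cc(/C=C/C(=O)c3ccc(N)cc3)[nH]n2)cc1`, -39%
- compound 2, `COc1cc(-c2cc(/C=C/C(=O)c3ccc(N)cc3)[nH]n2)cc(OC)c1OC`, -43%
- compound 3, `COc1cc(-c2cc(/C=C/C(=O)c3ccc(F)c(F)c3)[nH]n2)cc(OC)c1OC`, -14%

In a functional assay on A498 cells (Homo sapiens) for cytotoxicity, read by sulforhodamine B assay, with a stated time of 48 h, tested at 10 uM (on this read-out higher numbers stand for a weaker effect at the one concentration tested and lower numbers for a stronger effect), compound 2 gives the lowest of the three numbers. Within the data shown here, compound 1 is its nearest neighbour, and the two values lie within the usual scatter of each other, so the single methoxy of compound 1 and the three methoxy groups of compound 2 cannot be told apart on this read-out. Among the measured compounds shown here, compound 3 is furthest away: the step of a number 29 percentage points higher from compound 2 to compound 3 (beyond the scatter) is the only step that goes beyond the scatter, and it belongs to the exchange of the aminophenyl on the carbonyl carbon for a difluorophenyl.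

Compound 4, `COc1ccc(-c2cc(/C=C/C(=O)c3ccc(N)cc3)[nH]n2)cc1OC`, has not yet been measured. It differs from compound 2 in one place: hydrogen in place of methoxy on an aromatic carbon. For the measured compounds named here, no measured step touches the methoxy pattern of the shared core in isolation; the only pair that differs there, compound 1 and compound 2, shows two values within the scatter. Going by the values given here, the one step beyond the scatter, from compound 2 to compound 3, concerns the other end of the molecule and does not bear on this change. The expectation for a number 3 percentage points higher from compound 2 to compound 4 (within the scatter) is therefore a step of no size beyond the scatter, in no particular direction.

Compound 4 is thus estimated at -40%, with a range from -60% to -20%.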

Compound 4, a percentage reported as activity, at one concentration (the size of the read-out at that concentration, not a potency): -16%
Compound 4: the middle estimate sits 24 percentage points below what was measured, outside the stated range (above it).
By their numbers in this assay, from the lowest: compounds 2 and 1 (each within the scatter of the next); then compounds 4 and 3 (each within the scatter of the next).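

In this assay, the methoxy on the aromatic carbon ortho to a methoxy group and meta to a large group carries a real effect: replacing it with hydrogen gives a number 27 percentage points higher from compound 2 to compound 4 (beyond the scatter), whereas the similarity of compound 1 at -39% and compound 2 at -43% had suggested that the methoxy pattern made little difference. The reverse kind of change, methoxy in place of hydrogen on an aromatic carbon, moves the number the same way, with a number 23 percentage points higher from compound 1 to compound 4 (beyond the scatter), so both single-place changes that lead to compound 4 end in a weaker effect at the one concentration tested; the outcome of exchanging methoxy and hydrogen thus depends on the other groups on the ring, and no simple per-methoxy increment fits these three compounds. No measurement at hand accounts for this dependence.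

Still open, going by these compounds, is whether a hydroxy or ethoxy group at this place would behave like methoxy or like hydrogen. Also open, on these data alone, is whether the same dependence on the methoxy pattern holds when 3,4-difluorophenyl replaces 4-aminophenyl on the carbonyl carbon.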